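This account rests on a few compounds, and the source may have more. Where it says the series, first, only, none or still open, it means among the compounds named here.

Values in a toxicity assay on Huh-7 cells (Homo sapiens) for cytotoxicity, with a stated time of 3 days; on this read-out higher numbers stand for lower toxicity in this test and lower numbers for higher toxicity in this test:
- compound 1 `C[C@@]1(O)[C@H](O)[C@@H](CO)O[C@H]1n1cc(-c2ccc3ccccc3c2)c2c(N)ncnc21`: 20100 nM
- compound 2 `C[C@@]1(O)[C@H](O)[C@@H](CO)O[C@H]1n1cc(-c2cccs2)c2c(N)ncnc21`: 48100 nM

Compound 2 holds the higher of the two numbers in this assay. The next compound, compound 3 `C[C@@]1(O)[C@H](O)[C@@H](CO)O[C@H]1n1cc(-c2ccsc2)c2c(N)ncnc21`, is still unmeasured and carries thiophen-3-yl in place of thiophen-2-yl on an aromatic carbon. Compounds 2 and 3 have the same atoms, joined differently.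

Among the measured compounds shown here, only one measured step bears on this change: a 2.4-fold higher number from compound 1 to compound 2 (0.38 log units; beyond the scatter). That modest step replaced naphthalen-2-yl with thiophen-2-yl, a larger exchange than the one made here. For the measured compounds named here, no measured pair isolates a change of thiophene attachment, so the expectation is loose: no step beyond the usual scatter, and no preferred direction. The expected step is a 1.1-fold lower number from compound 2 to compound 3 (0.03 log units; within the scatter). Compound 3 is estimated at 45000 nM, with an expected range of 22000 nM to 90000 nM.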

Compound 3, half-maximal cytotoxic concentration: > 44000 nM
Compound 3: no number, only a limit; the forecaster's own chance of this, stated with the estimate: 15%; the middle value lies beyond the limit too.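

In this assay compound 3 gives a limit and not a number: > 44000 nM. Against the naphthalen-2-yl group at this position, thiophen-3-yl gives an at least 2.1-fold higher number from compound 1 to compound 3 (0.34 log units; beyond the scatter), so the second thiophene attachment moves the same way as a 2.4-fold higher number from compound 1 to compound 2 (0.38 log units; beyond the scatter), and the higher readings at this position are not confined to thiophen-2-yl. The change from thiophen-2-yl to thiophen-3-yl itself cannot be read, because one of its two ends is only a limit: the limit of > 44000 nM in this assay, at which 1 of the 3 values shown sits.

On these data alone, how far compound 3 lies past its limit in this assay remains open, and with it any order between the two thiophene attachments. Also open is where a phenyl group, an amine or a carboxylic acid at this position would fall relative to the three compounds shown.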